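The source may report more compounds than this note shows. Statements on the series, on what has been measured and on what is new or still open speak of the compounds shown alone.

Measured compounds

compound 1 `C=CC1=C(C(=O)NCC(C)C)C(c2ccc(OC)cc2)OC1`: in a functional assay on A549 cells (Homo sapiens) for cytotoxicity, read by MTT assay, with a stated time of 24 h (a lower number here means a stronger inhibitor, a higher number a weaker inhibitor), compound 1 gives > 100000 nM, which is a limit of the assay and not a number.
compound 2 `C=CC1=C(C(=O)NCc2ccc(C)cc2)C(c2ccc(OC)cc2)OC1`: in this assay compound 2 gives > 100000 nM, again a limit of the assay rather than a number.

Compound 2 therefore stands at the top end of what this assay reports; both values shown so far sit there, as recorded in the limit of > 100000 nM in this assay, at which 2 of the 2 values shown sit. Going by the values given here, the one measured step at this position, a step that the two limits leave unreadable from compound 1 to compound 2, runs between two limits and cannot be read for size or direction.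

Compound 3 `C=CC1=C(C(=O)NCc2ccccc2F)C(c2ccc(OC)cc2)OC1` differs from compound 2 by 2-fluorophenyl in place of 4-methylphenyl on a saturated chain carbon bound to an amide-type nitrogen. The only measured step that bears on this place is the one from compound 1 to compound 2, and it is unreadable; no step here has shown a change beyond the scatter, and nothing in the series so far points toward cytotoxicity appearing with a change of this kind. The expected step that the limit leaves unreadable from compound 2 to compound 3 from compound 2 to compound 3 is accordingly none beyond the scatter. For compound 3 the estimate in this assay is 150000 nM, with a range from 50000 nM to 500000 nM, and the most likely outcome is that the assay again reports only a limit.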

Compound 3, half-maximal inhibitory concentration: > 100000 nM
Compound 3 ended at the assay's limit (the forecaster's own chance of this, stated with the estimate: 85%); the middle value does not contradict the limit.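

In this assay compound 3 gives > 100000 nM, a limit of the assay and not a number. No new step can therefore be read among compound 1, compound 2 and compound 3, whose values all rest at the same limit: the limit of > 100000 nM in this assay, at which 3 of the 3 values shown sit.

The compounds shown leave open whether any group on a saturated chain carbon bound to an amide-type nitrogen, or any change to the shared core, gives a measurable value in this series.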